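The source may hold more compounds than are shown below. What is called first, only, known or untested is meant among the compounds shown, and "the series" means these compounds.

In a functional assay on A549 cells (Homo sapiens) for antiproliferative activity, read by CCK-8 assay, with a stated time of 72 h (a lower number here means a stronger inhibitor, a higher number a weaker inhibitor), compound 1 `Cc1ccc(C(=O)Nc2cccc(-c3oc4cc(-c5ccc(F)cc5)ccc4c(=O)c3O)c2)cc1` gives 6910 nM. Compound 2 `O=C(Nc1cccc(-c2oc3cc(-c4ccc(F)cc4)ccc3c(=O)c2O)c1)c1ccc(Cl)cc1` gives 10800 nM and compound 3 `COc1cccc(C(=O)Nc2cccc(-c3oc4cc(-c5ccc(F)cc5)ccc4c(=O)c3O)c2)c1` gives 10800 nM; compound 2 thus stands level with compound 3 at the digits shown, the two together being the highest of the three numbers. Compound 4 `CCc1ccc(C(=O)Nc2cccc(-c3oc4cc(-c5ccc(F)cc5)ccc4c(=O)c3O)c2)cc1` differs from compound 2 by ethyl in place of chloro on an aromatic carbon. The measured step that bears most on this change is the one that put chloro in place of methyl on an aromatic carbon, where a 1.6-fold higher number from compound 1 to compound 2 (0.19 log units; within the scatter); the remaining steps, a 1.6-fold higher number from compound 1 to compound 3 (0.19 log units; within the scatter) and no change at the digits printed from compound 2 to compound 3 (within the scatter), exchange the whole aryl group and also stay within the scatter. No step beyond the scatter is therefore expected in this assay, the anticipated change being a 1.4-fold lower number from compound 2 to compound 4 (0.13 log units; within the scatter). Compound 4 is estimated at 8000 nM, with a range from 3500 nM to 18000 nM.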

Compound 4, half-maximal inhibitory concentration: 18500 nM
Compound 4: middle estimate off by 2.3-fold (0.36 log units), on the low side, and the stated range ends below it.
By their numbers in this assay, from the lowest: compounds 1, 2, 3 and 4 (each within the scatter of the next, the first and the last beyond it).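

Notes on the 4-position of the aryl group on the amide carbonyl in this assay: ethyl in place of chloro stays within the scatter (a 1.7-fold higher number from compound 2 to compound 4 (0.23 log units; within the scatter)), as does 4-ethylphenyl in place of 3-methoxyphenyl (a 1.7-fold higher number from compound 3 to compound 4 (0.23 log units; within the scatter)). Within the data shown here, the only step here beyond the scatter is the modest one that extends methyl to ethyl (a 2.7-fold higher number from compound 1 to compound 4 (0.43 log units; beyond the scatter)), so this position responds to that small change in the alkyl group. Nothing measured here accounts for that step.

Open, going by these compounds, is whether propyl or a longer chain continues this rise in number. On these data alone, how an amine or a carboxylic acid at this position would read also remains open.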